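EP4 series: sulfonyl swap on the pyridyl analogue

A few compounds are considered here, and "the series" means these few. Any claim that something is new, unique, unknown or untested is made for them only; others in the source may bear on it.

Measured so far in an assay on cells for displacement of a labelled ligand from prostaglandin E2 receptor EP4 subtype (Homo sapiens), read by scintillation counting; on this read-out lower numbers stand for stronger inhibition and higher numbers for weaker inhibition:
compound 1 `COc1ccc(-c2ccc(OCc3cc(C(=O)NS(=O)(=O)c4ccccc4)oc3C)cc2)cc1` — 5 nM
compound 2 `COc1ccc(-c2ccc(OCc3cc(C(=O)NS(=O)(=O)c4c(C)noc4C)oc3C)cc2)c(C)c1` — 24 nM
compound 3 `COc1ccc(-c2ccc(OCc3cc(C(=O)NS(=O)(=O)c4ccccc4)oc3C)cc2)nc1` — 22 nM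

Compound 3 stands second highest of the three numbers. Among the measured compounds shown here, its nearest neighbour is compound 2, which gives 24 nM in this assay, a gap within the scatter; the one measured step that reaches it, a 4.4-fold higher number from compound 1 to compound 3 (0.64 log units; beyond the scatter), is modest and beyond the scatter.

Compound 4 `COc1ccc(-c2ccc(OCc3cc(C(=O)NS(=O)(=O)c4c(C)noc4C)oc3C)cc2)nc1` is the next member. The change from compound 3 reads (3,5-dimethyl-1,2-oxazol-4-yl in place of phenyl on a sulfonyl sulfur). For the measured compounds named here, no measured step isolates this change: compound 2 carries the same 3,5-dimethyl-1,2-oxazol-4-yl on its sulfonyl sulfur, but it also differs from compound 1 in a second place, so the pair of compound 1 at 5 nM and compound 2 at 24 nM shows only what the sulfonyl swap and that second change amount to together, not what the sulfonyl swap alone may cost. The structural change is therefore expected to give, at most, a small step in this assay toward a higher number, and possibly none beyond the scatter.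

On that basis compound 4 is estimated at 40 nM in this assay, within 15 nM to 120 nM. The step this estimate implies is a 1.8-fold higher number from compound 3 to compound 4 (0.26 log units; within the scatter), and it remains an expectation only.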

Compound 4, inhibition constant: 13 nM
Compound 4: middle estimate off by 3.1-fold (0.49 log units), on the high side; measured number outside the range, below it.
By their numbers in this assay, from the lowest: compound 1; then compounds 4, 3 and 2 (each within the scatter of the next).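

Notes on the sulfonyl position: in this assay, the swap to 3,5-dimethyl-1,2-oxazol-4-yl in place of phenyl on the sulfonyl sulfur can now be read alone, and it gives a 1.7-fold lower number from compound 3 to compound 4 (0.23 log units; within the scatter), so with the 5-methoxypyridin-2-yl group held constant, compound 3 and compound 4 cannot be told apart. With the 3,5-dimethyl-1,2-oxazol-4-yl group held constant, 5-methoxypyridin-2-yl in place of 4-methoxy-2-methylphenyl on an aromatic carbon gives a 1.8-fold lower number from compound 2 to compound 4 (0.27 log units; within the scatter), so this aryl change also stays inside the scatter, unlike the change from 4-methoxyphenyl, which gave a 4.4-fold higher number from compound 1 to compound 3 (0.64 log units; beyond the scatter). No supporting data bear on why either new step is this small.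

The compounds shown leave open whether the sulfonyl swap would read the same with 4-methoxyphenyl on the aromatic carbon, since compound 1 has no partner differing from it only at the sulfonyl sulfur. They also leave open what a methyl group on the sulfonyl sulfur, or a carboxylic acid in place of the whole (phenylsulfonyl)amino unit, would give in this assay.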